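Adding a Second Chloro Group: What to Expect

The source may hold more compounds than are shown below. What is called first, only, known or untested is meant among the compounds shown, and "the series" means these compounds.

Measured so far:
compound 1 `ClCc1ccc(Cn2cnc3c(Cl)ncnc32)cc1`: > 100000 nM
compound 2 `ClCc1cccc(Cn2cnc3c(Cl)ncnc32)c1`: > 100000 nM

Of the compounds shown here, two have been tested in a functional assay on MCF7 cells (Homo sapiens) for cytotoxicity, read by sulforhodamine B assay, with a stated time of 48 h; on this read-out higher numbers stand for lower toxicity in this test and lower numbers for higher toxicity in this test. Compound 1 `ClCc1ccc(Cn2cnc3c(Cl)ncnc32)cc1` gives > 100000 nM, which is a limit of the test and not a number. Compound 2 `ClCc1cccc(Cn2cnc3c(Cl)ncnc32)c1` gives > 100000 nM, likewise a limit and not a number. Compound 2 therefore stands at the limit of > 100000 nM in this assay, at which 2 of the 2 values shown sit, and nothing can be said about any order between the two compounds.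

Compound 3 `ClCc1cccc(Cn2cnc3c(Cl)nc(Cl)nc32)c1` has not yet been measured. It differs from compound 2 by chloro in place of hydrogen on an aromatic carbon. For the measured compounds named here, no step between two measured compounds is available, so there is no measured guide to what this change does in this test. Going by the values given here, since both values known so far sit at the limit, the step is expected to be a number no higher from compound 2 to compound 3 (the limit leaves the size open), nothing beyond the scatter, with a good chance that only a limit is reported again. Compound 3 is expected to give 100000 nM, with a range from 30000 nM to 300000 nM.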

Compound 3, concentration lethal to 50% of the cells: > 100000 nM
Compound 3: a limit, no number; the forecaster's own chance of this, stated with the estimate: 70%; the middle value lies on the limit itself.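

In this assay, for the compounds shown here, compound 2 and compound 3 both stand at a limit of the test and not at a number, so no step for chloro in place of hydrogen on an aromatic carbon can be read from this pair. The compounds shown leave open whether any change to them would give a real number in this test.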